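From 2-methylphenyl to 3-methoxyphenyl on the sulfonamide nitrogen

The source may hold more compounds than are shown below. What is called first, only, known or untested is meant among the compounds shown, and "the series" means these compounds.

Measured so far in a functional assay on MCF7 cells (Homo sapiens) for antiproliferative activity, read by sulforhodamine B assay, with a stated time of 48 h; on this read-out lower numbers stand for stronger inhibition and higher numbers for weaker inhibition:
compound 1 `CCc1ccccc1NS(=O)(=O)c1ccc(N2CCNC2=O)cc1` gives 350 nM
compound 2 `Cc1ccc(NS(=O)(=O)c2ccc(N3CCNC3=O)cc2)c(C)c1` gives 230 nM
compound 3 `Cc1ccccc1NS(=O)(=O)c1ccc(N2CCNC2=O)cc1` gives 280 nM

Compound 3 cannot be set apart from the other two. The data show a 1.2-fold higher number from compound 2 to compound 3 (0.09 log units; within the scatter) and a 1.3-fold lower number from compound 1 to compound 3 (0.10 log units; within the scatter), so its place among the three values carries no meaning.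

Compound 4 `COc1cccc(NS(=O)(=O)c2ccc(N3CCNC3=O)cc2)c1` has not yet been measured. It carries 3-methoxyphenyl in place of 2-methylphenyl on a sulfonamide nitrogen and otherwise keeps the core of compound 3. The measured steps bear on this change only in part. All of them alter the group on that nitrogen, and the remaining one, a 1.5-fold lower number from compound 1 to compound 2 (0.18 log units; within the scatter), is also small. Within the data shown here, none of the measured compounds has a methoxy group, so the evidence is indirect. On these small steps, no change beyond the scatter is expected in this assay, though with a wide margin. The expected step is a 1.3-fold higher number from compound 3 to compound 4 (0.10 log units; within the scatter), with no firm direction. The estimate for compound 4 is 350 nM, with an expected range from 100 nM to 1300 nM.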

Compound 4, half-maximal inhibitory concentration: 120 nM
Beside the measured number, compound 4's estimate is 2.9-fold (0.46 log units) above it; the measured number falls inside the stated range.
By their numbers in this assay, from the lowest: compounds 4, 2, 3 and 1 (each within the scatter of the next, the first and the last beyond it).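

In this assay, among these compounds, changing the group on the sulfonamide nitrogen moves the number beyond the scatter for the first time, with 3-methoxyphenyl replacing 2-methylphenyl (a 2.3-fold lower number from compound 3 to compound 4 (0.37 log units; beyond the scatter)) and replacing 2-ethylphenyl (a 2.9-fold lower number from compound 1 to compound 4 (0.46 log units; beyond the scatter)), both steps modest. The position therefore responds to the group it carries, but only in part: with 3-methoxyphenyl replacing 2,4-dimethylphenyl (a 1.9-fold lower number from compound 2 to compound 4 (0.28 log units; within the scatter)), compound 4 stays within the scatter of compound 2 and cannot be called the strongest of the four. No measurement shown here accounts for the difference.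

The compounds shown leave open whether the lower number belongs to the methoxy group itself or to its place on the ring. They also do not tell whether an ethoxy or a hydroxyl group in its stead would keep that number.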